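Swapping a Furan for a Methylpyridine: Expected Clearance

A few compounds are considered here, and "the series" means these few. Any claim that something is new, unique, unknown or untested is made for them only; others in the source may bear on it.

Of the compounds shown here, three sharing one core have been measured in an ADME assay (liver) for metabolic stability, with Liver microsome (Homo sapiens) as the target, using microsomes and NADPH, with a stated time of 30 min, tested at 1 uM; a lower number here means slower removal, a higher number faster removal of the compound. Compound 1 `Nc1ccc(S(=O)(=O)N2CCN(c3ncc(C(O)(C(F)(F)F)C(F)(F)F)cc3C3CC3)CC2)cn1` gives 38 mL.min-1.g-1 in this assay. Compound 2 `CC(C)(C)n1cc(-c2cc(C(O)(C(F)(F)F)C(F)(F)F)cnc2N2CCN(S(=O)(=O)c3ccc(N)nc3)CC2)cn1`, with 1-(tert-butyl)-1H-pyrazol-4-yl in place of cyclopropyl on an aromatic carbon, gives 86 mL.min-1.g-1, which is a 2.3-fold higher number from compound 1 to compound 2 (0.35 log units; beyond the scatter). Compound 3 `Nc1ccc(S(=O)(=O)N2CCN(c3ncc(C(O)(C(F)(F)F)C(F)(F)F)cc3-c3ccoc3)CC2)cn1` carries furan-3-yl in place of cyclopropyl on an aromatic carbon. For compound 3 this assay returns only a limit, < 14 mL.min-1.g-1, so its exact position is not known (the limit of < 14 mL.min-1.g-1 in this assay, at which 1 of the 3 values shown sits). That limit still amounts to an at least 2.7-fold lower number from compound 1 to compound 3 (0.43 log units; beyond the scatter) and to an at least 6.1-fold lower number from compound 2 to compound 3 (0.78 log units; beyond the scatter), placing compound 3 at the slow end of the three.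

Compound 4 `Cc1ccc(-c2cc(C(O)(C(F)(F)F)C(F)(F)F)cnc2N2CCN(S(=O)(=O)c3ccc(N)nc3)CC2)cn1` differs from compound 3 by 6-methylpyridin-3-yl in place of furan-3-yl on an aromatic carbon. The two measured steps that bear on this change both replace one group on that same aromatic carbon, and they pull in opposite directions: the five-membered furan-3-yl lowered the number, whereas the larger 1-(tert-butyl)-1H-pyrazol-4-yl raised it. A six-membered aromatic ring with 1 hetero atom bearing a methyl sits between those cases, so a modest rise from the limit of compound 3 is expected, as an at least 2.1-fold higher number from compound 3 to compound 4 (0.33 log units; beyond the scatter). Compound 4 is therefore estimated at 30 mL.min-1.g-1, with a likely range from 14 mL.min-1.g-1 to 75 mL.min-1.g-1.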

Compound 4, intrinsic clearance in microsomes: 43 mL.min-1.g-1
Compound 4: middle estimate off by 1.4-fold (0.16 log units), on the low side, within the range that was stated.
By their numbers in this assay, from the lowest: compounds 1, 4 and 2 (each within the scatter of the next, the first and the last beyond it). At a limit, below all of these: compound 3.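

In this assay, the aromatic carbon ortho to a large group now shows that the low number of compound 3 is not shared by every aromatic ring placed there: the change to 6-methylpyridin-3-yl gives an at least 3.0-fold higher number from compound 3 to compound 4 (0.48 log units; beyond the scatter). The two other new steps, a 1.1-fold higher number from compound 1 to compound 4 (0.05 log units; within the scatter) and a 2.0-fold lower number from compound 2 to compound 4 (0.30 log units; within the scatter), stay within the scatter, while the step of a 2.3-fold higher number from compound 1 to compound 2 (0.35 log units; beyond the scatter) lies beyond it, so of the four groups on this carbon only furan-3-yl stands apart from all three others. The size of that separation remains a minimum, since compound 3 is known only as a limit: the limit of < 14 mL.min-1.g-1 in this assay, at which 1 of the 4 values shown sits.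

The compounds shown leave open whether the low number goes with the oxygen of furan-3-yl, with the five-membered ring or with the lack of a methyl, as furan-3-yl and 6-methylpyridin-3-yl differ in all of these at once. A pyridin-3-yl without the methyl or a thiophen-3-yl on the same carbon would begin to separate these features.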